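This account rests on a few compounds, and the source may have more. Where it says the series, first, only, none or still open, it means among the compounds named here.

Among the compounds with values here, compound 1 `O=c1[nH]c2ccccc2cc1-c1nc2cc(Br)ccc2[nH]1` is the one compound in this set that returns a number rather than a limit: in a functional assay on HepG2 cells (Homo sapiens) for cytotoxicity, read by MTT assay, with a stated time of 48 h (a higher number here means a weaker inhibitor, a lower number a stronger inhibitor), compound 1 gives 10800 nM. Compound 2 `Cc1ccc2[nH]c(=O)c(-c3nc4ccccc4[nH]3)cc2c1` reaches only a limit in this assay, namely > 100000 nM. Compound 3 `Cc1ccc2[nH]c(=O)c(-c3nc4cc(Br)ccc4[nH]3)cc2c1` likewise shows only a limit in this assay, > 100000 nM. Two of the three values thus sit at the limit of > 100000 nM in this assay, at which 2 of the 3 values shown sit. Within the data shown here, the single readable step is an at least 9.2-fold higher number from compound 1 to compound 3 (0.96 log units; beyond the scatter), whereas the step that the two limits leave unreadable from compound 2 to compound 3 cannot be sized. Compound 4 `O=c1[nH]c2ccccc2cc1-c1nc2cc(Cl)ccc2[nH]1` differs from compound 1 by chloro in place of bromo on an aromatic carbon. Among the measured compounds shown here, no measured step exchanges one halogen for another, and the only step touching bromo is unreadable, so no step beyond the scatter is expected in this assay, a 1.1-fold lower number from compound 1 to compound 4 (0.03 log units; within the scatter). Compound 4 is therefore estimated at 10000 nM, between 4000 nM and 25000 nM.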

Compound 4, half-maximal inhibitory concentration: 8450 nM
Beside the measured number, compound 4's estimate is 1.2-fold (0.07 log units) above it, within the range that was stated.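

In this assay, the only exchange of one halogen for another shown stays within the scatter: a 1.3-fold lower number from compound 1 to compound 4 (0.11 log units; within the scatter). Within the data shown here, at this place on the aromatic carbon, chloro and bromo are therefore not told apart, which the earlier compounds, with a single number among them, could not show. Nothing given here bears on a cause for this result. From the compounds shown here alone, whether an amine, a carboxylic acid or a longer chain at this place would give a similar number stays open. Going by these compounds, it also stays open whether chloro would give a readable number on a core that also carries methyl.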